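Amine swap on the shared core of compound 1

The compounds below may be only part of what the source reports. "The series", "measured", "known", "first", "only" and "open" are said of these compounds alone.

For the measured compounds named here, compound 1 `CCN(Cc1ccc(F)cc1)c1ccc(C(=O)N2CCc3ccc(OS(N)(=O)=O)cc3C2)cc1` gives the highest number of the three measured members in an assay on HEK293 cells for inhibition of Steryl-sulfatase (Homo sapiens), tested at 0.1 uM (on this read-out higher numbers stand for a stronger effect at the one concentration tested and lower numbers for a weaker effect), at 69.1%. Compound 3 `CC(C)CCN(CCC(C)C)c1cccc(C(=O)N2CCc3ccc(OS(N)(=O)=O)cc3C2)c1` stands nearest, giving 32.3% in this assay, and compound 2 `NS(=O)(=O)Oc1ccc2c(c1)CN(C(=O)c1cccc(N3CCCCC3)c1)CC2` stands furthest, giving 1%; both gaps to compound 1 lie beyond the scatter. Going by the values given here, the only measured step that alters the amino group on the aromatic carbon is a number 31.3 percentage points higher from compound 2 to compound 3 (beyond the scatter), which shows that this assay answers strongly to what sits at that position.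

Compound 4 `CCCN(Cc1ccccc1)c1ccc(C(=O)N2CCc3ccc(OS(N)(=O)=O)cc3C2)cc1` differs from compound 1 at the same kind of position: benzyl(propyl)amino in place of ethyl(4-fluorobenzyl)amino on an aromatic carbon. That step between compound 2 and compound 3 is the one that bears on the present change, and it was large; it exchanged a ring-closed amine for an open-chain one, whereas here both groups carry a benzyl ring and a short chain on the nitrogen and the counts of heavy atoms, donors and acceptors match. Among the compounds with values here, no measured pair tests this narrower exchange, so the expectation rests on the step being small, likely within the scatter, with a slight downward lean as compound 1 already stands highest. The estimated step is a number 7.1 percentage points lower from compound 1 to compound 4 (within the scatter). Compound 4 is therefore expected to give about 62% in this assay, within 45% to 78%.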

Compound 4, a percentage reported as inhibition, at one concentration (the size of the read-out at that concentration, not a potency): 64.8%
The estimate for compound 4 lay 2.8 percentage points below the measured number; the range from low to high includes it.
By their numbers in this assay, from the lowest: compound 2; then compound 3; then compounds 4 and 1 (each within the scatter of the next).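

In this assay, benzyl(propyl)amino in place of ethyl(4-fluorobenzyl)amino gives a number 4.3 percentage points lower from compound 1 to compound 4 (within the scatter) and so leaves the read-out unchanged within the usual scatter. For the compounds shown here, the earlier step, a number 31.3 percentage points higher from compound 2 to compound 3 (beyond the scatter) on the same read-out, showed only that an exchange of amine can move the number a long way; the new step shows that not every exchange of amine does so. Two amines that each carry a benzyl ring and a short chain on the nitrogen thus sit together at the top of the series, well clear of compound 3 and compound 2, and no measurement at hand accounts for the closeness of their numbers.

The fluorine and the chain length change together in this one step, so a small effect from each of them cannot be told apart from no effect at all; ethyl(benzyl)amino or propyl(4-fluorobenzyl)amino would separate the two. Also open, as far as these compounds go, is how the read-out responds when the benzyl ring gives way to a pyridylmethyl group, when the chain on the nitrogen grows to butyl or hexyl, or when a carboxylic acid is placed on the benzyl ring.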